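From 2-Chlorobenzyl to 3-Chlorobenzyl in Two Related Series

The compounds below may be only part of what the source reports. "The series", "measured", "known", "first", "only" and "open" are said of these compounds alone.

Compound 1 `COc1ccc(C2N=C(SCc3ccccc3Cl)NC(C)=C2C(=O)Nc2ccc(F)cc2)cc1OC` — 35.9%
Compound 2 `COc1ccc(C2N=C(SCc3cccc(Cl)c3)NC(C)=C2C(=O)Nc2ccc(F)cc2)cc1OC` — 16.4%
Compound 3 `CC1=C(C(=O)Nc2ccc([N+](=O)[O-])cc2)C(c2ccc(Br)cc2)N=C(SCc2ccccc2Cl)N1` — 16.9%

Three compounds were examined in a functional assay on the whole organism (artery, strain albino) with Rattus norvegicus as the target, with a stated time of 300 min, at a dose of 10 mg/kg by the oral route; a higher number here means more inhibition at the dose given (going by the name of the read-out), a lower number less inhibition. Compound 1 gave 35.9%, while compound 2, in which (3-chlorophenyl in place of 2-chlorophenyl on a saturated chain carbon bound to a sulfur), gave 16.4%. This change produced a number 19.5 percentage points lower from compound 1 to compound 2 (beyond the scatter). Compound 3 gave 16.9%; the values of compound 2 and compound 3 lie within the scatter of each other, so no order between them is claimed. The difference between the core of compound 1 and the core of compound 3 is not broken down here.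

Compound 4 `CC1=C(C(=O)Nc2ccc([N+](=O)[O-])cc2)C(c2ccc(Br)cc2)N=C(SCc2cccc(Cl)c2)N1` has not yet been measured in this assay. Relative to compound 3, (3-chlorophenyl in place of 2-chlorophenyl on a saturated chain carbon bound to a sulfur). This is the same change as that from compound 1 to compound 2, made at the same place. Within the data shown here, since the single earlier example of this change gave a number 19.5 percentage points lower from compound 1 to compound 2 (beyond the scatter), a step of similar direction is expected from compound 3 to compound 4, namely a number 10.9 percentage points lower from compound 3 to compound 4 (beyond the scatter), with the caution that only one measured pair supports it and that compound 3 starts from a lower level than compound 1 did. Compound 4 is therefore estimated at 6%, with a range from -8% to 20%.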

Compound 4, a percentage reported as inhibition, in the whole organism at one dose (the size of the read-out at that dose, not a potency): 9.2%
The estimate for compound 4 lay 3.2 percentage points below the measured number; measured number inside the range.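

On the core of compound 3, the change from 2-chlorobenzyl to 3-chlorobenzyl in this assay gave a number 7.7 percentage points lower from compound 3 to compound 4 (within the scatter). Set beside the earlier example of the same change, the two steps cannot be told apart in size: the same change on two cores in this assay, a number 19.5 percentage points lower (beyond the scatter) from compound 1 to compound 2 and a number 7.7 percentage points lower (within the scatter) from compound 3 to compound 4, 11.8 percentage points apart, within the scatter of two such steps. Among these compounds, the two steps point the same way, which fits the change carrying over from one core to the other, but this does not establish a transferable effect, as only the step on the core of compound 1 stands clear of the scatter and two pairs cannot fix its size.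

The compounds shown leave open how a plain benzyl group or a longer alkyl chain on the sulfur would compare with the two chlorobenzyl groups in this assay. They also leave open whether the same step would appear on a third core, and which of the differences between the core of compound 1 and the core of compound 3 matter for the read-out.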